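A few compounds are considered here, and "the series" means these few. Any claim that something is new, unique, unknown or untested is made for them only; others in the source may bear on it.

Measured so far:
- compound 1, `COc1cc(Cc2nc3c(N)ncnc3n2CC2CCCO2)cc(OC)c1OC`: 91200 nM
- compound 2, `COc1cc(Cc2nc3c(N)nc(F)nc3n2CC2CCCO2)cc(OC)c1OC`: 22900 nM
- compound 3, `C=CCCn1c(Cc2cc(OC)c(OC)c(OC)c2)nc2c(N)nc(F)nc21`: 33100 nM

Compound 1 has the highest number of the three in a functional assay on MCF7 cells (Homo sapiens) for antiproliferative activity; on this read-out lower numbers stand for stronger inhibition and higher numbers for weaker inhibition. Compound 2 lies a 4.0-fold lower number from compound 1 to compound 2 (0.60 log units; beyond the scatter). Compound 3 sits close to compound 2, the pair being separated by a 1.4-fold higher number from compound 2 to compound 3 (0.16 log units; within the scatter).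

The next compound is compound 4, `COc1cc(Cc2nc3c(N)ncnc3n2C)cc(OC)c1OC`. Against compound 1 it carries the change (hydrogen in place of oxolan-2-yl on a saturated chain carbon bound to an aromatic nitrogen).

Among the measured compounds shown here, no measured step removes this group in favour of hydrogen. For the measured compounds named here, the one step that touches the same place is the exchange of oxolan-2-yl for allyl, and there compound 2 and compound 3 differ by a 1.4-fold higher number from compound 2 to compound 3 (0.16 log units; within the scatter) only, within the scatter. That points to this position tolerating a different group without a clear shift in this assay, though the move to hydrogen is a larger cut than the move to allyl, and compounds 2 and 3 additionally carry fluoro on an aromatic carbon, which compounds 1 and 4 do not.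

Compound 4 is therefore expected to sit near compound 1, with an expected step of a 1.2-fold higher number from compound 1 to compound 4 (0.08 log units; within the scatter), not beyond the scatter. The estimate for compound 4 is 110000 nM, between 45000 nM and 280000 nM.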

Compound 4, half-maximal inhibitory concentration: 70800 nM
Compound 4: the middle estimate sits 1.6-fold (0.19 log units) above what was measured, within the range that was stated.
By their numbers in this assay, from the lowest: compounds 2 and 3 (each within the scatter of the next); then compounds 4 and 1 (each within the scatter of the next).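

In this assay, cutting (oxolan-2-yl)methyl back to methyl gives a 1.3-fold lower number from compound 1 to compound 4 (0.11 log units; within the scatter), so in the compounds without fluoro the oxolan-2-yl group can be lost entirely with no clear shift in the read-out. The earlier compounds shown here touched this place only through the exchange of oxolan-2-yl for allyl, and only with fluoro present; this pair extends that tolerance to a removal of the group, not just its replacement by another carbon chain. No measured data bear on why the step stays so small, so the flat response at this position remains an observation without an explanation.

Oxolan-2-yl, allyl and hydrogen are all the position has to show so far, so it remains open whether an amine, a carboxylic acid or a longer chain on the saturated chain carbon bound to the aromatic nitrogen would also leave the read-out unchanged. On these data alone, it is also open whether the effect of fluoro on an aromatic carbon, seen as a 4.0-fold lower number from compound 1 to compound 2 (0.60 log units; beyond the scatter), carries over to compound 4, which has methyl in place of (oxolan-2-yl)methyl.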